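Anilino for dipropylamino on two isomeric cores

This account rests on a few compounds, and the source may have more. Where it says the series, first, only, none or still open, it means among the compounds named here.

The set holds compound 1 `CCCN(CCC)C1=CC(=O)c2nc3n(c2C1=O)[C@H]1OC[C@@H](O)[C@H]1OC3`, compound 2 `O=C1C=C(Nc2cccc(Cl)c2)C(=O)c2c1nc1n2[C@H]2OC[C@@H](O)[C@H]2OC1`, compound 3 `CCCN(CCC)C1=CC(=O)c2c(nc3n2[C@H]2OC[C@@H](O)[C@H]2OC3)C1=O` and the not yet measured compound 4 `O=C1C(Nc2cccc(Cl)c2)=CC(=O)c2c1nc1n2[C@H]2OC[C@@H](O)[C@H]2OC1`. Compound 1 and compound 3 are built from the same atoms joined differently; the difference between the two cores is not broken down here. In a functional assay on ECa-109 cells for inhibition, with ECa-109 cell line (Homo sapiens) as the target, read by sulforhodamine B assay (on this read-out lower numbers stand for stronger inhibition and higher numbers for weaker inhibition), compound 1 gives > 16000 nM, which is a limit of the assay and not a number. Compound 3 gives > 16000 nM in this assay, again a limit. Compound 2 gives 4690 nM in this assay. The step of an at least 3.4-fold lower number from compound 1 to compound 2 (0.53 log units; beyond the scatter) is known only as a bound because of the limit of > 16000 nM in this assay, at which 2 of the 3 values shown sit. The change behind it is (3-chlorophenyl)amino in place of dipropylamino on a double-bonded ring carbon. Compound 4 carries the same change on the core of compound 3, ((3-chlorophenyl)amino in place of dipropylamino on a double-bonded ring carbon), at the same place on the ring system. A step of an at least 2.9-fold lower number from compound 3 to compound 4 (0.46 log units; beyond the scatter) is expected. That expectation rests on compound 1 and compound 2 and their step of an at least 3.4-fold lower number from compound 1 to compound 2 (0.53 log units; beyond the scatter), with the remaining uncertainty that the second core is a different one. Compound 4 is estimated at 5500 nM, expected between 2000 nM and 16000 nM.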

Compound 4, half-maximal inhibitory concentration: 3080 nM
The estimate for compound 4 lay 1.8-fold (0.25 log units) above the measured number; the measured number falls inside the stated range.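

Carried to the core of compound 3, (3-chlorophenyl)amino in place of dipropylamino on a double-bonded ring carbon again lowers the number in this assay, with a step of an at least 5.1-fold lower number from compound 3 to compound 4 (0.71 log units; beyond the scatter). The change therefore runs in the same direction on both cores, which is as far as the transfer can be stated from this pair of cores: the same change on two cores in this assay, an at least 3.4-fold lower number (0.53 log units; beyond the scatter) from compound 1 to compound 2 and an at least 5.1-fold lower number (0.71 log units; beyond the scatter) from compound 3 to compound 4; the limit leaves it open whether they differ. What is not shown is whether the change is worth the same amount on each core, and both steps remain bounds, not sizes, because the two dipropylamino compounds give only a limit of the assay: the limit of > 16000 nM in this assay, at which 2 of the 4 values shown sit.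

Still open, going by these compounds, is how a plain phenylamino group without the chlorine, a morpholine or a short monoalkylamine would read on either core. Also open, on these data alone, is whether the aromatic ring or the hydrogen on the amine nitrogen carries the step, since the change brings in both at once.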